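Bromo to nitrile on the benzyl arm: expected cytotoxicity

A few compounds are considered here, and "the series" means these few. Any claim that something is new, unique, unknown or untested is made for them only; others in the source may bear on it.

Compound 3 `COC(=O)c1ccc(NCc2cncn2Cc2cccc(Br)c2)cc1-c1ccccc1` is one of three close relatives built on the shared core. In a toxicity assay on NIH3T3 cells (Mus musculus) for cytotoxicity, read by resazurin assay (a lower number here means that less compound is needed, a higher number that more compound is needed for the effect), compound 3 gives > 10000 nM, which is a limit of the assay rather than a number. Compound 2 `COC(=O)c1ccc(NCc2cncn2Cc2cccc(Cl)c2)cc1-c1ccccc1` gives > 10000 nM in this assay, also a limit. Compound 1 `COC(=O)c1ccc(NCc2cncn2Cc2ccccc2OC)cc1-c1ccccc1` shows "not determined" (no result reported) in this assay. Within the data shown here, the one measured step, a step that the two limits leave unreadable from compound 2 to compound 3, cannot be sized because of the limit of > 10000 nM in this assay, at which 2 of the 3 values shown sit. Compound 4 `COC(=O)c1ccc(NCc2cncn2Cc2ccccc2C#N)cc1-c1ccccc1` differs from compound 3 by 2-cyanophenyl in place of 3-bromophenyl on a saturated chain carbon bound to an aromatic nitrogen. No readable step bears on this change, so no movement beyond the scatter is expected. The expected step is a step that the limit leaves unreadable from compound 3 to compound 4. Compound 4 is therefore estimated at 15000 nM, with a range from 5000 nM to 50000 nM, most likely reported again as a limit.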

Compound 4, half-maximal effective concentration: 25000 nM
For compound 4 the middle estimate is 1.7-fold (0.22 log units) below the measured one; the measured number falls inside the stated range.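

Neither step to compound 4, from compound 2 or from compound 3, can be sized, because both of those compounds sit at a limit of the assay: the limit of > 10000 nM in this assay, at which 2 of the 4 values shown sit. The compounds shown leave open how far any change on the benzyl arm moves the result in this assay and whether it matters at all.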